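This account rests on a few compounds, and the source may have more. Where it says the series, first, only, none or still open, it means among the compounds named here.

Measured so far in a functional assay (muscle tissue) with Cavia porcellus as the target; on this read-out lower numbers stand for stronger inhibition and higher numbers for weaker inhibition:
Compound 1 `CC1=NC(C)=C([N+](=O)[O-])C(c2cccc(Cl)n2)/C1=C(/O)OC(C)C` gives 16700 nM.
Compound 2 `CC1=NC(C)=C([N+](=O)[O-])C(c2cccc(C)n2)/C1=C(/O)OCCc1ccccc1` gives 9980 nM.
Compound 3 `CC1=NC(C)=C([N+](=O)[O-])C(c2cccc(C(F)(F)F)n2)/C1=C(/O)OCCc1ccccc1` gives 1410 nM.

Compound 3 thus gives the lowest of the three numbers in this assay, well beyond the scatter from compound 2 and further still from compound 1. Compound 4 `CC1=NC(C)=C([N+](=O)[O-])C(c2cccc(Cl)n2)/C1=C(/O)OCCc1ccccc1` differs from compound 3 only in chloro in place of trifluoromethyl on an aromatic carbon. Going by the values given here, one measured step bears on this change: a 7.1-fold lower number from compound 2 to compound 3 (0.85 log units; beyond the scatter). Among the compounds with values here, compound 1, which also carries the chloro group but a different ester, gives the highest number of the three, yet no single-change step links it to compound 4. Trifluoromethyl leaving is therefore expected to give back part of that gain, so a modest rise in this assay is expected, a 2.8-fold higher number from compound 3 to compound 4 (0.45 log units; beyond the scatter). Compound 4 is estimated at 4000 nM, within 1500 nM to 10000 nM.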

Compound 4, half-maximal inhibitory concentration: 1510 nM
Compound 4: the middle estimate sits 2.6-fold (0.42 log units) above what was measured; low and high end bracket the measured number.
By their numbers in this assay, from the lowest: compounds 3 and 4 (each within the scatter of the next); then compounds 2 and 1 (each within the scatter of the next).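

In this assay, chloro in place of trifluoromethyl at this place gives a 1.1-fold higher number from compound 3 to compound 4 (0.03 log units; within the scatter), so the two groups cannot be told apart here, while chloro in place of methyl gives a 6.6-fold lower number from compound 2 to compound 4 (0.82 log units; beyond the scatter). With chloro held fixed, phenethyl in place of isopropyl on the ester oxygen gives an 11-fold lower number from compound 1 to compound 4 (1.04 log units; beyond the scatter), which shows that this side of the molecule also matters. Nothing shown explains these results. Going by these compounds, it remains open whether a methoxy group or an amine at this place would match chloro or methyl, and whether the phenethyl step holds with trifluoromethyl.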